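The source may hold more compounds than are shown below. What is called first, only, known or untested is meant among the compounds shown, and "the series" means these compounds.

Among the compounds with values here, compound 2 `C=CCN(Cc1cccs1)C(=O)COc1ccc(C)cc1` is one of two compounds measured so far in an assay on HEK293 cells for agonist activity at transient receptor potential cation channel subfamily M member 8 (Homo sapiens), read by fluorescence and calcium flux, with a stated time of 15 min (a lower number here means that less compound is needed, a higher number that more compound is needed for the effect), and stands at the higher of the two numbers: in this assay compound 2 gives 20 nM, while compound 1 `CCN(Cc1cccs1)C(=O)COc1ccc(C)cc1` gives 8 nM. Within the data shown here, the only measured step, a 2.5-fold higher number from compound 1 to compound 2 (0.40 log units; beyond the scatter), shows that a change at this same position already shifted the number upward. Compound 3 `Cc1ccc(OCC(=O)N(CCCO)Cc2cccs2)cc1` differs from compound 2 in one place: 2-hydroxyethyl in place of vinyl on a saturated chain carbon bound to an amide-type nitrogen. Among the measured compounds shown here, no measured step covers a hydroxyl group entering at this position, so the expectation rests solely on the single earlier step, which was modest and pointed toward a higher number. A further change at the same position, this time bringing in a group counted with one hydrogen-bond donor and one hydrogen-bond acceptor, is therefore expected to give a modest step in the same direction in this assay, though the uncertainty is wide. Compound 3 is estimated at 40 nM, within a range from 10 nM to 200 nM. That estimate is expected to correspond to a step of a 2.0-fold higher number from compound 2 to compound 3 (0.30 log units; within the scatter).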

Compound 3, half-maximal effective concentration: 3000 nM
Beside the measured number, compound 3's estimate is 75-fold (1.88 log units) below it, outside the stated range (above it).
By their numbers in this assay, from the lowest: compound 1; then compound 2; then compound 3.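

In this assay, allyl giving way to 3-hydroxypropyl produces a 150-fold higher number from compound 2 to compound 3 (2.18 log units; beyond the scatter), a far larger step than the modest 2.5-fold higher number from compound 1 to compound 2 (0.40 log units; beyond the scatter), so the earlier pair gave no hint of how much this position can respond to a change. Read from the other measured neighbour, hydroxymethyl in place of hydrogen on a saturated chain carbon, two bonds along the chain from an amide-type nitrogen, gives a 380-fold higher number from compound 1 to compound 3 (2.57 log units; beyond the scatter), so the large rise appears against both earlier compounds. Compound 3 is also the first of the three to carry a hydrogen-bond donor and acceptor in this chain, and here that change goes with much more compound being needed for the effect.

Nothing available explains why the number rises so steeply. As far as these compounds go, the three compounds also cannot separate the hydroxyl from the change in the chain itself, and it remains open how a plain propyl chain, a methyl ether or an amine in place of the hydroxyl, or a carboxylic acid on this chain would compare.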